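Distal ring replacements in a bombesin receptor subtype-3 agonist series

A few compounds are considered here, and "the series" means these few. Any claim that something is new, unique, unknown or untested is made for them only; others in the source may bear on it.

Measured in a functional assay on HEK293 cells for agonist activity at Bombesin receptor subtype-3 (Mus musculus), read by luminescence and calcium flux, with a stated time of 10 min; on this read-out higher numbers stand for an effect only at larger amounts of compound and lower numbers for an effect already at smaller amounts:
compound 1 `CCC(C)(C)Cc1c[nH]c(CCc2ccc(-n3ncnn3)cc2)n1`: 99 nM
compound 2 `CCC(C)(C)Cc1c[nH]c(CCc2ccc(-c3ccccc3C(=O)O)cc2)n1`: 94 nM
compound 3 `CCC(C)(C)Cc1c[nH]c(CCc2ccc(-c3cccc(N)n3)cc2)n1`: 119 nM

Compound 3 gives the highest of the three numbers, yet it is not set apart: a 1.2-fold higher number from compound 1 to compound 3 (0.08 log units; within the scatter) and a 1.3-fold higher number from compound 2 to compound 3 (0.10 log units; within the scatter) both fall within the usual scatter, so the three measured compounds are indistinguishable on this read-out.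

Compound 4 `CCC(C)(C)Cc1c[nH]c(CCc2ccc(-c3csnn3)cc2)n1` continues the same exchange at the same position of the shared core: 1,2,3-thiadiazol-4-yl in place of 6-aminopyridin-2-yl on an aromatic carbon. The group that enters is, like the tetrazolyl of compound 1, a small five-membered aromatic ring with several hetero atoms and no hydrogen-bond donor, whereas the group that leaves carries a donor.

Among the measured compounds shown here, the steps that bear on this change are the three measured swaps at this position: a 1.1-fold lower number from compound 1 to compound 2 (0.02 log units; within the scatter), a 1.2-fold higher number from compound 1 to compound 3 (0.08 log units; within the scatter) and a 1.3-fold higher number from compound 2 to compound 3 (0.10 log units; within the scatter). None of them moved the number beyond the scatter, although the groups exchanged differ widely in size, donor count and ring type. No step beyond the scatter is therefore expected for this assay on going from compound 3 to compound 4, with a slight lean toward the value of compound 1 because a 1.2-fold higher number from compound 1 to compound 3 (0.08 log units; within the scatter) was the step from the other five-membered ring.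

Compound 4 is estimated at 100 nM, within 45 nM to 230 nM, meaning an expected 1.2-fold lower number from compound 3 to compound 4 (0.08 log units; within the scatter).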

Compound 4, half-maximal effective concentration: 109 nM
For compound 4 the middle estimate is 1.1-fold (0.04 log units) below the measured one, and the stated range covers the measured number.
By their numbers in this assay, from the lowest: compounds 2, 1, 4 and 3 (each within the scatter of the next).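

In this assay, the 1,2,3-thiadiazol-4-yl group is the only sulfur-bearing ring among the compounds at this position, and it leaves the number unresolved from every earlier group: a 1.1-fold lower number from compound 3 to compound 4 (0.04 log units; within the scatter), a 1.1-fold higher number from compound 1 to compound 4 (0.04 log units; within the scatter) and a 1.2-fold higher number from compound 2 to compound 4 (0.06 log units; within the scatter). The flat response now extends to a second five-membered aromatic ring with several hetero atoms, and the exchange for 6-aminopyridin-2-yl shows that a smaller ring with no hydrogen-bond donor is accepted on this aromatic carbon, para to a large group, without a step beyond the scatter. No supporting measurement is available to explain why these four groups give indistinguishable numbers.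

All four groups shown are aromatic rings, so it remains open whether a saturated ring such as piperidine, a simple amide or a short alkyl chain at this position would also stay within the scatter. Going by these compounds, it also remains open whether a hydrogen atom in place of the ring would leave the number unchanged, which would indicate how much of the agonist activity depends on any group here.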